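Bile acid receptor series: compound 1 to compound 3

The compounds below may be only part of what the source reports. "The series", "measured", "known", "first", "only" and "open" are said of these compounds alone.

Measured so far:
compound 1, `Cc1ccccc1-n1nc(C)c2c1NC(=O)[C@H](C)S[C@@H]2c1ccc(/C=C/c2ccccc2)cc1`: "not active" (no number reported)
compound 2, `Cc1cccc(-n2nc(C)c3c2NC(=O)[C@H](C)S[C@@H]3c2ccc(Oc3ccccc3)cc2)c1`: 2400 nM

For the measured compounds named here, in an assay on isolated protein for agonist activity at Bile acid receptor (Homo sapiens), read by AlphaScreen, with a stated time of 30 min (a lower number here means that less compound is needed, a higher number that more compound is needed for the effect), compound 1 is reported as "not active" (no number reported), so no single number stands for it and no step can be counted from it. In this assay compound 2 gives 2400 nM; compound 2 differs from compound 1 in more than one place, so the two values are only set side by side here.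

Compound 3, `Cc1ccccc1-n1nc(C)c2c1NC(=O)[C@H](C)S[C@@H]2c1ccc(OCc2ccccc2)cc1`, is the next case. It differs from compound 1 by benzyloxy in place of 2-phenylethenyl on an aromatic carbon. Going by the values given here, with compound 1 carrying no number, neither size nor direction of the step can be framed against the scatter; the only anchor is compound 2, whose phenoxy also links the outer phenyl through oxygen and which gives 2400 nM. On that footing compound 3 is expected to return a number, and its value in this assay is estimated at 5000 nM, within 1500 nM to 30000 nM, with a real chance of a limit only.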

Compound 3, half-maximal effective concentration: "not active" (no number reported)
Compound 3 has no reported number here; the estimate stays without a comparison.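

Compound 3, like compound 1, is reported without a number in this assay and so no step can be read between them. The compounds shown leave open whether benzyloxy and 2-phenylethenyl differ at all at this place. No measured evidence bears on this result.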